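The source may report more compounds than this note shows. Statements on the series, on what has been measured and on what is new or still open speak of the compounds shown alone.

Measured compounds:
compound 1, `COc1cccc(C(=O)N2CCCCC2CCOc2ccc(Cl)c(Cl)c2)c1`, 501 nM
compound 2, `O=C(NC[C@@H]1CCCCN1C(=O)c1ccccc1-c1ccccc1)c1ccccc1`, 20 nM
compound 3, `CN(C[C@@H]1CCCCN1C(=O)c1ccccc1-c1ccccc1)C(=O)c1ccc(F)cc1`, 1260 nM

All three were tested in a functional assay on CHO cells for antagonist activity at Orexin receptor type 2 (Homo sapiens), read by FLIPR; a lower number here means a stronger inhibitor, a higher number a weaker inhibitor. Compound 2 has the lowest number of the three: compound 1 gives 501 nM and compound 3 gives 1260 nM, and both of those gaps to compound 2 lie well beyond the scatter, so compound 2 is the strongest inhibitor here. Compound 3 shares the core of compound 2 but carries a methyl group on the amide nitrogen in place of the amide hydrogen.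

Compound 4, `O=C(CC[C@@H]1CCCCN1C(=O)c1ccccc1-c1ccccc1)c1ccccc1`, has not yet been measured in this assay. It differs from compound 2 in one place: benzoylmethyl in place of benzamido on a saturated chain carbon bound to a saturated ring carbon. Like compound 3, compound 4 no longer carries the amide hydrogen, though it replaces it differently. A weaker result than compound 2 is expected because compound 3 gives 1260 nM, though the size of that loss in compound 4 is uncertain. Compound 4 is expected to give about 300 nM, with a plausible range from 60 nM to 1500 nM. The expected step from compound 2 to compound 4 is a 15-fold higher number from compound 2 to compound 4 (1.18 log units; beyond the scatter), a weakening beyond the scatter.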

Compound 4, inhibition constant: 20 nM
Estimate against measurement, compound 4: 15-fold (1.18 log units) above, outside the stated range (below it).
By their numbers in this assay, from the lowest: compounds 2 and 4 (each within the scatter of the next); then compound 1; then compound 3.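

In this assay replacing benzamido with benzoylmethyl on a saturated chain carbon bound to a saturated ring carbon gives no change at the digits printed from compound 2 to compound 4 (within the scatter) and so shows that, in this pair, neither the amide nitrogen nor the amide hydrogen is needed to keep this level of inhibition. Compound 3 also lacks the amide hydrogen and gives 1260 nM but differs from compound 2 in more than one place, so its weaker number cannot be pinned on the loss of that hydrogen alone. No measurement offered here explains why these two groups perform alike.

From the compounds shown here alone, whether the carbonyl kept by both compounds matters at this position remains open, and an amine or an ether in its place would test that. A longer chain carrying the same benzoyl group is also an open question.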